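Compound 1 to compound 4: tert-butyl for phenyl

A few compounds are considered here, and "the series" means these few. Any claim that something is new, unique, unknown or untested is made for them only; others in the source may bear on it.

Compound 1 `O=C(NCc1cc(Cl)ccc1-n1cnnn1)[C@@H]1CC=NN1C(=O)[C@H](O)c1ccccc1` gives < 12 mL.min-1.g-1
Compound 2 `CC(C)(C)[C@@H](O)C(=O)N1OCC[C@H]1C(=O)NCc1cc(Cl)ccc1-n1cnnn1` gives < 12 mL.min-1.g-1
Compound 3 `CC(C)(C)C[C@@H](O)C(=O)N1C[C@@H]2C[C@@H]2[C@H]1C(=O)NCc1cc(Cl)ccc1-n1cnnn1` gives 20 mL.min-1.g-1

In an ADME assay on liver for metabolic stability, with Liver microsome (Homo sapiens) as the target, read by LC-MS, using microsomes (on this read-out lower numbers stand for slow clearance and higher numbers for fast clearance), compound 1 stands at the limit of < 12 mL.min-1.g-1 in this assay, at which 2 of the 3 values shown sit, and has a limit rather than a number. Compound 4 `CC(C)(C)[C@@H](O)C(=O)N1N=CC[C@H]1C(=O)NCc1cc(Cl)ccc1-n1cnnn1` is unmeasured and differs from compound 1 by tert-butyl in place of phenyl on a saturated chain carbon bound to a carbonyl carbon and an oxygen on a saturated carbon in the structure. Compound 2 also carries (1-hydroxy-2,2-dimethylpropyl)carbonyl and its < 12 mL.min-1.g-1 is likewise a limit. The expected step is a step that the limit leaves unreadable from compound 1 to compound 4 and no shift beyond the scatter is expected in this assay in either direction. For compound 4 the estimated value is 10 mL.min-1.g-1 (expected range 5 mL.min-1.g-1 to 20 mL.min-1.g-1) .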

Compound 4, intrinsic clearance in microsomes: < 12 mL.min-1.g-1
Compound 4: no number, only a limit; the forecaster's own chance of this, stated with the estimate: 65%; the middle value is on the limit's open side.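

In this assay, going by these compounds alone, compound 1 and compound 4 both carry limits rather than numbers, so no step between them can be read. The compounds shown leave open whether tert-butyl in place of phenyl shifts the read-out in this assay at all.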